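A few compounds are considered here, and "the series" means these few. Any claim that something is new, unique, unknown or untested is made for them only; others in the source may bear on it.

Compound 3 `O=C(CN1CCN(c2ccc(Cl)c(Cl)c2)CC1)N(c1ccccc1)c1ccccc1` carries a 3,4-dichlorophenyl on the ring amine nitrogen of the shared core. In a functional assay on the whole organism (strain Swiss albino) for inhibition, with Mus musculus as the target, with stated times of 10 min, 5 min and 20 min (on this read-out higher numbers stand for an effect only at larger amounts of compound and lower numbers for an effect already at smaller amounts), compound 3 gives 24 mg/kg. Among the two numbers shown this is the higher one, yet compound 2 `O=C(CN1CCN(c2cccc(C(F)(F)F)c2)CC1)N(c1ccccc1)c1ccccc1`, which gives 21.3 mg/kg in this assay, sits so close that the step of a 1.1-fold higher number from compound 2 to compound 3 (0.05 log units; within the scatter) is within the scatter. Compound 1 `Cc1ccc(N2CCN(CC(=O)N(c3ccccc3)c3ccccc3)CC2)cc1` gives only a limit of the assay, > 20 mg/kg, in this assay. That limit (the limit of > 20 mg/kg in this assay, at which 1 of the 3 values shown sits) leaves the steps a step that the limit leaves unreadable from compound 1 to compound 2 and a step that the limit leaves unreadable from compound 1 to compound 3 without a readable size.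

Compound 4 `O=C(CN1CCN(c2ccc(F)cc2)CC1)N(c1ccccc1)c1ccccc1` differs from compound 3 in one place: 4-fluorophenyl in place of 3,4-dichlorophenyl on an amine nitrogen in a ring. For the measured compounds named here, no measured step involves a 4-fluorophenyl, and the one readable aryl swap, from compound 2 to compound 3, changed nothing beyond the scatter. On that basis the step of a 1.0-fold higher number from compound 3 to compound 4 (0.02 log units; within the scatter) is expected to stay within the scatter. Compound 4 is therefore estimated to give 25 mg/kg in this assay, with an expected range from 12 mg/kg to 55 mg/kg.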

Compound 4, dose for half-maximal effect: 13.4 mg/kg
The estimate for compound 4 lay 1.9-fold (0.27 log units) above the measured number; low and high end bracket the measured number.
By their numbers in this assay, from the lowest: compounds 4, 2 and 3 (each within the scatter of the next).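

Compound 4 adds a third readable aryl group on this amine nitrogen in a ring, and in this assay the change to 4-fluorophenyl stays within the scatter from both larger groups (a 1.8-fold lower number from compound 3 to compound 4 (0.25 log units; within the scatter); a 1.6-fold lower number from compound 2 to compound 4 (0.20 log units; within the scatter)). So, across compounds 2, 3 and 4, neither the single fluorine nor the loss of the chlorines or the trifluoromethyl gives a change that can be told from scatter. Compound 1 gives a limit and not a number, which leaves only a floor (an at least 1.4-fold lower number from compound 1 to compound 4 (0.17 log units; that floor lies within the scatter)) and makes its other steps unreadable: the limit of > 20 mg/kg in this assay, at which 1 of the 4 values shown sits.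

Still open, on these data alone, is whether an amine or a carboxylic acid on this phenyl ring would move the number beyond the scatter. Also open, as far as these compounds go, is what a longer chain before the amide carbonyl would do.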